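The source may report more compounds than this note shows. Statements on the series, on what has been measured and on what is new or still open speak of the compounds shown alone.

In a functional assay on A549 cells (Homo sapiens) for antiproliferative activity, read by MTT assay, with a stated time of 48 h (on this read-out higher numbers stand for weaker inhibition and lower numbers for stronger inhibition), compound 1 (`CCOc1cc(-c2ccc3cc[nH]c3c2)cn2c(-c3cc(OC)c(OC)c(OC)c3)nnc12`) gives 626 nM and compound 2 (`CCOc1cc(-c2ccc3[nH]ccc3c2)cn2c(-c3cc(OC)c(OC)c(OC)c3)nnc12`) gives 589 nM, which places compound 2 level with compound 1 at the low end of the numbers. Compound 3 (`COc1cc(-c2nnc3c(OC4COC4)cc(-c4ccc5[nH]ccc5c4)cn23)cc(OC)c1OC`) gives 9810 nM. Compound 4 (`CCOc1cc(-c2ccc3ccn(C)c3c2)cn2c(-c3cc(OC)c(OC)c(OC)c3)nnc12`) differs from compound 2 on an aromatic carbon: 1-methyl-1H-indol-6-yl in place of 1H-indol-5-yl on an aromatic carbon. The swap between 1H-indol-6-yl and 1H-indol-5-yl bears most directly, and a 1.1-fold lower number from compound 1 to compound 2 (0.03 log units; within the scatter) lies within the scatter. The large 17-fold higher number from compound 2 to compound 3 (1.22 log units; beyond the scatter) arose elsewhere, on an oxygen, so it says little here. Going by the values given here, no measured step covers the added methyl. No step beyond the scatter is therefore expected in this assay, and the estimated step is a 1.2-fold lower number from compound 2 to compound 4 (0.07 log units; within the scatter). Compound 4 is expected at 500 nM, within an estimated range of 150 nM to 1700 nM.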

Compound 4, half-maximal inhibitory concentration: 349 nM
Beside the measured number, compound 4's estimate is 1.4-fold (0.16 log units) above it; the range from low to high includes it.
By their numbers in this assay, from the lowest: compounds 4, 2 and 1 (each within the scatter of the next); then compound 3.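

In this assay a methyl in place of hydrogen on the aromatic nitrogen of 1H-indol-6-yl brings a 1.8-fold lower number from compound 1 to compound 4 (0.25 log units; within the scatter) and the change from 1H-indol-5-yl to 1-methyl-1H-indol-6-yl brings a 1.7-fold lower number from compound 2 to compound 4 (0.23 log units; within the scatter) and neither step leaves the scatter. At this position, then, the group can lose its hydrogen-bond donor and gain one heavy atom with no step beyond the scatter in these compounds. Nothing measured here speaks to why.

The compounds shown leave open whether a longer chain such as propyl, or an amine, on that aromatic nitrogen would stay within this range. They also leave open whether 1-methyl-1H-indol-5-yl would do the same.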